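The source may hold more compounds than are shown below. What is called first, only, known or untested is meant among the compounds shown, and "the series" means these compounds.

Measured compounds:
compound 1, `CCCCCCCCCCCCCCCCCc1ncc2cnnc(S)n12`; in a functional assay for inhibition, with Homo sapiens as the target (on this read-out higher numbers stand for weaker inhibition and lower numbers for stronger inhibition), compound 1 gives > 48000 nM, a limit of the assay.
compound 2, `CCCc1nc(Br)c2cnnc(O)n12`; in this assay compound 2 gives > 48000 nM, also a limit of the assay.
compound 3, `CCc1ncn2c(Nc3cc[nH]n3)nccc12`; in this assay compound 3 gives 36000 nM.

Within the data shown here, compound 3 stands as the only actual number in this assay; the other two values are limits, as the limit of > 48000 nM in this assay, at which 2 of the 3 values shown sit, states. Among the measured compounds shown here, no step between measured compounds is available, so the three compounds can only be set side by side, and a limit is not a number to compare.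

Compound 4, `CC(C)c1ncn2c(Nc3cc[nH]n3)nccc12`, is not yet measured. It differs from compound 3 by methyl in place of hydrogen on a saturated chain carbon bound to an aromatic carbon and a saturated chain carbon. For the measured compounds named here, with no measured step to lean on, the change is expected to move this assay by no more than the usual scatter, in either direction. Compound 4 is therefore expected to give about 30000 nM in this assay, within 12000 nM to 70000 nM. The expected step reads a 1.2-fold lower number from compound 3 to compound 4 (0.08 log units; within the scatter). Compound 1 and compound 2 returned only limits in this assay, and there is a fair chance that compound 4 returns only a limit as well.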

Compound 4, half-maximal inhibitory concentration: > 48000 nM
Compound 4 ended at the assay's limit; the forecaster's own chance of this, stated with the estimate: 35%; at least 1.6-fold (0.20 log units) between middle value and limit.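

Going from ethyl to isopropyl gives an at least 1.3-fold higher number from compound 3 to compound 4 (0.12 log units; that floor lies within the scatter) in this assay, the first step that can be read in this series. Compound 4 gives > 48000 nM, which is a limit of the assay. The step is therefore only a floor: the added methyl on this saturated chain carbon brought no gain in inhibition, but the change is not shown to exceed the scatter, and the series still holds a single real number: the limit of > 48000 nM in this assay, at which 3 of the 4 values shown sit.

On these data alone, how far compound 4 truly lies from compound 3 remains open, as the limit hides its actual value. Also open, as far as these compounds go, is whether a longer chain, a methoxy group or an amine at this same place would give a lower number in this assay.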